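A few compounds are considered here, and "the series" means these few. Any claim that something is new, unique, unknown or untested is made for them only; others in the source may bear on it.

Of the compounds shown here, three built on one shared core have been tested in a functional assay on HCT-15 cells (Homo sapiens) for cytotoxicity, read by sulforhodamine B assay, with a stated time of 72 h; on this read-out higher numbers stand for weaker inhibition of growth and lower numbers for stronger inhibition of growth. Compound 1 `CC(=O)N1c2ccccc2CCC1C(=O)Nc1ccccc1O` gives 54500 nM. Compound 2 `O=C(Nc1ccccc1C(F)(F)F)C1CCc2ccccc2N1` gives 40400 nM. Compound 3 `CCCCCCCCC(=O)N1c2ccccc2CCC1C(=O)Nc1ccccc1O` gives 38400 nM. Compound 3 therefore holds the lowest of the three numbers, yet its gap to compound 2 and its gap to compound 1 both lie within the scatter of repeated measurements, so the three cannot be placed in order. Going by the values given here, the one single-site step among them, a 1.4-fold lower number from compound 1 to compound 3 (0.15 log units; within the scatter), is likewise within the scatter: lengthening the acyl chain on the ring nitrogen changed nothing that can be trusted.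

Compound 4 `O=C(Nc1ccccc1O)C1CCc2ccccc2N1` differs from compound 3 in one place: hydrogen in place of octylcarbonyl on a nitrogen on an aromatic ring in a ring. The measured step that bears most directly on this position, a 1.4-fold lower number from compound 1 to compound 3 (0.15 log units; within the scatter), says that altering the group on this nitrogen left the number essentially unmoved. Compound 2 also carries a hydrogen on that nitrogen, with a trifluoromethyl rather than a hydroxy on the amide-bound ring, and its value sits within the scatter of the value of compound 3. On this evidence the step from compound 3 to compound 4 is expected to be none beyond the scatter, a 1.0-fold higher number from compound 3 to compound 4 (0.02 log units; within the scatter). Compound 4 is therefore estimated at 40000 nM, with a range from 15000 nM to 110000 nM.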

Compound 4, concentration for 50% growth inhibition: 5610 nM
Beside the measured number, compound 4's estimate is 7.1-fold (0.85 log units) above it, and the stated range ends above it.
By their numbers in this assay, from the lowest: compound 4; then compounds 3, 2 and 1 (each within the scatter of the next).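

In this assay, where a lower number means stronger inhibition of growth, the group on the ring nitrogen turns out to matter: removing the acyl group altogether gives a 6.8-fold lower number from compound 3 to compound 4 (0.84 log units; beyond the scatter) and a 9.7-fold lower number from compound 1 to compound 4 (0.99 log units; beyond the scatter), although exchanging acetyl for octylcarbonyl had moved the number by no more than the scatter. The hydrogen on that nitrogen is not enough on its own, since compound 2 carries it too, and hydroxy in place of trifluoromethyl on an aromatic carbon gives a 7.2-fold lower number from compound 2 to compound 4 (0.86 log units; beyond the scatter); among these four compounds, only compound 4 combines that hydrogen with the hydroxy, and only compound 4 stands apart from the others. No measurement shown here explains why either change has this effect.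

From the compounds shown here alone, it remains open whether a single methyl on the ring nitrogen would keep the lower number of compound 4 or would behave like the acetyl of compound 1. Going by these compounds, it is equally open whether an amine or a carboxylic acid could take the place of the hydroxy on the aromatic ring without losing that gain.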